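A few compounds are considered here, and "the series" means these few. Any claim that something is new, unique, unknown or untested is made for them only; others in the source may bear on it.

Measured compounds:
compound 1 `O=S(=O)(NCC1CCN(CCCc2c[nH]c3ccc(-n4cnnc4)cc23)CC1)c1ccccc1` — 6.2 nM
compound 2 `CC(C)=CCCN(C)C1CCN(CCCc2c[nH]c3ccc(-n4cnnc4)cc23)CC1` — 2.6 nM
compound 3 `CN(Cc1ccccc1)CC1CCN(CCCc2c[nH]c3ccc(-n4cnnc4)cc23)CC1` — 0.9 nM

All values are from an assay on CHO cells for displacement of a labelled ligand from 5-hydroxytryptamine receptor 1D (Homo sapiens); on this read-out higher numbers stand for weaker inhibition and lower numbers for stronger inhibition. Compound 1 stands highest of the three; nearest is compound 2 with a 2.4-fold lower number from compound 1 to compound 2 (0.38 log units; beyond the scatter), furthest compound 3 with a 6.9-fold lower number from compound 1 to compound 3 (0.84 log units; beyond the scatter). Compound 2 and compound 3 differ by a 2.9-fold lower number from compound 2 to compound 3 (0.46 log units; beyond the scatter).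

Compound 4 `c1ccc2c(c1)CCC2NCC1CCN(CCCc2c[nH]c3ccc(-n4cnnc4)cc23)CC1` is not yet measured. Against compound 1 it carries 2,3-dihydro-1H-inden-1-yl in place of phenylsulfonyl on an amine nitrogen. Both measured steps away from compound 1 remove the phenylsulfonyl group and lower the number; the larger, a 6.9-fold lower number from compound 1 to compound 3 (0.84 log units; beyond the scatter), also keeps a six-membered aromatic ring of carbon near the amine nitrogen, as compound 4 does. A lower number in this assay is therefore expected for compound 4, a step of about a 4.1-fold lower number from compound 1 to compound 4 (0.62 log units; beyond the scatter). Estimate for compound 4: 1.5 nM, range 0.5 nM to 5 nM.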

Compound 4, half-maximal inhibitory concentration: 1.1 nM
The estimate for compound 4 lay 1.4-fold (0.13 log units) above the measured number, and the stated range covers the measured number.
By their numbers in this assay, from the lowest: compounds 3 and 4 (each within the scatter of the next); then compound 2; then compound 1.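

Replacing phenylsulfonyl with 2,3-dihydro-1H-inden-1-yl on this amine nitrogen in this assay gives a 5.6-fold lower number from compound 1 to compound 4 (0.75 log units; beyond the scatter) with the number of heavy atoms unchanged, so a lower number does not depend on a tertiary amine at this site. The (2,3-dihydro-1H-inden-1-yl)amino and benzyl(methyl)amino groups are not separated, with a 1.2-fold higher number from compound 3 to compound 4 (0.09 log units; within the scatter) as the step. Against the open-chain group of compound 2, the step is a 2.4-fold lower number from compound 2 to compound 4 (0.37 log units; beyond the scatter) and also beyond the scatter.

From the compounds shown here alone, whether a cyclohexyl group on the same nitrogen would match compound 4 remains open. Nothing available explains these steps.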